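The source may report more compounds than this note shows. Statements on the series, on what has been measured and on what is new or still open speak of the compounds shown alone.

Measured compounds in an assay (Cricetulus griseus) for inhibition of aldehyde dehydrogenase, mitochondrial (Homo sapiens); a lower number here means a stronger inhibitor, a higher number a weaker inhibitor:
compound 1, `O=C(O)CCCCOc1ccc2c(=O)c(-c3ccc(O)cc3)coc2c1`: 100 nM
compound 2, `CC(Oc1ccc2c(=O)c(-c3ccc(O)cc3)coc2c1)C(=O)O`: 2500 nM

Compound 2 stands at the highest number of the two, its nearest neighbour being compound 1 at a lower number; the measured step between them, a 25-fold higher number from compound 1 to compound 2 (1.40 log units; beyond the scatter), is large. Compound 3, `C=CCCCCOc1ccc2c(=O)c(-c3ccc(O)cc3)coc2c1`, has not yet been measured. Relative to compound 2 it carries hex-5-en-1-yl in place of 1-carboxyethyl on an oxygen on an aromatic ring. Among the compounds with values here, only one measured step bears on this change, a 25-fold higher number from compound 1 to compound 2 (1.40 log units; beyond the scatter), which accompanied a shortening of the chain on the aromatic oxygen from 4-carboxybutyl to 1-carboxyethyl. Within the data shown here, compound 3 returns to a chain of about the length found in compound 1 while dropping the carboxyl; the chain-length part of the change is therefore expected to undo much of that step, but the missing carboxyl has no counterpart among the measured compounds, so the size of the reversal is uncertain. For compound 3 a step of a 10-fold lower number from compound 2 to compound 3 (1.00 log units; beyond the scatter) toward a lower number is expected. The estimate for compound 3 is 250 nM, with a range from 60 nM to 1200 nM.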

Compound 3, half-maximal inhibitory concentration: 150 nM
Compound 3: middle estimate off by 1.7-fold (0.22 log units), on the high side; the range from low to high includes it.
By their numbers in this assay, from the lowest: compounds 1 and 3 (each within the scatter of the next); then compound 2.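

In this assay, vinyl in place of carboxy on a saturated chain carbon, four bonds along the chain from an oxygen on an aromatic ring, gives a 1.5-fold higher number from compound 1 to compound 3 (0.18 log units; within the scatter) and leaves the two compounds indistinguishable, so a carboxy group at the chain end is not needed to reach this level. The change at the oxygen on the aromatic ring gives a 17-fold lower number from compound 2 to compound 3 (1.22 log units; beyond the scatter), and the entering hex-5-en-1-yl has no hydrogen-bond donor or acceptor, which places compound 2 alone among the three, with 1-carboxyethyl as the only substituent of its kind on this oxygen. No measurement shown here accounts for either step.

In 1-carboxyethyl, a shorter chain, a branch and a carboxylic acid all occur together, so a short neutral chain such as ethyl and an unbranched 2-carboxyethyl chain would be needed to separate these features. Going by these compounds, the response to a longer chain, or to an amine at the chain end, also remains open, as does whether the terminal alkene of hex-5-en-1-yl matters compared with a saturated hexyl chain.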